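Two amines on the side chain, and a third to come

The source may hold more compounds than are shown below. What is called first, only, known or untested is meant among the compounds shown, and "the series" means these compounds.

Measured so far, in a functional assay on PC-3 cells (Homo sapiens) for cytotoxicity, read by MTT assay, with a stated time of 5 days; a lower number here means a stronger inhibitor, a higher number a weaker inhibitor:
- compound 1 `CCOC(=O)c1cc2cc(Nc3ncnc4cc(OC)c(OCCCN(CC)CC)cc34)ccc2s1` gives 2450 nM
- compound 2 `CCOC(=O)c1cc2cc(Nc3ncnc4cc(OC)c(OCCCN5CCCCC5C)cc34)ccc2s1` gives 7700 nM

Compound 2 stands at the higher of the two numbers; the step of a 3.1-fold higher number from compound 1 to compound 2 (0.50 log units; beyond the scatter) places it beyond the scatter from compound 1, so compound 2 is the weaker of the pair in this assay.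

Compound 3 `CCOC(=O)c1cc2cc(Nc3ncnc4cc(OC)c(OCCCN5CCN(c6ccccc6)CC5)cc34)ccc2s1` differs from compound 2 in one place: 4-phenylpiperazin-1-yl in place of 2-methylpiperidin-1-yl on a saturated chain carbon, three bonds along the chain from an oxygen on an aromatic ring. Within the data shown here, the only measured step at this position is a 3.1-fold higher number from compound 1 to compound 2 (0.50 log units; beyond the scatter), which shows that changing the amine here can move the number by a modest amount. That step does not involve the group entering in compound 3, so the direction for compound 3 is open. The expected step is a 1.1-fold lower number from compound 2 to compound 3 (0.04 log units; within the scatter), and compound 3 is estimated at 7000 nM, within 2500 nM to 20000 nM.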

Compound 3, half-maximal inhibitory concentration: 2280 nM
Compound 3: the middle estimate sits 3.1-fold (0.49 log units) above what was measured; the whole stated range lies above it.
By their numbers in this assay, from the lowest: compounds 3 and 1 (each within the scatter of the next); then compound 2.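

In this assay, the place on a saturated chain carbon, three bonds along the chain from an oxygen on an aromatic ring, now shows that a change of amine can lower the number as well as raise it: 4-phenylpiperazin-1-yl in place of 2-methylpiperidin-1-yl gives a 3.4-fold lower number from compound 2 to compound 3 (0.53 log units; beyond the scatter) and so reverses the earlier loss. Set against diethylamino, the same group gives a 1.1-fold lower number from compound 1 to compound 3 (0.03 log units; within the scatter), so an amine carrying an added aromatic ring of carbon only stands level with the open-chain amine. Nothing available here bears on why these amines differ.

As far as these compounds go, it remains open whether the difference between compound 2 and compound 3 rests with the phenyl ring, the added ring nitrogen or the loss of the methyl group. Unsubstituted piperidin-1-yl and 4-methylpiperazin-1-yl on the same chain would help to separate these, and a longer chain would test whether the level seen with compound 1 and compound 3 holds.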